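The source may report more compounds than this note shows. Statements on the series, on what has been measured and on what is new or still open speak of the compounds shown alone.

In a toxicity assay on NIH3T3 cells (Mus musculus) for cytotoxicity, read by resazurin assay (on this read-out higher numbers stand for an effect only at larger amounts of compound and lower numbers for an effect already at smaller amounts), compound 1 `COC(=O)c1ccc(NCc2cncn2Cc2cccc(-c3ccccc3)c2)cc1-c1ccccc1` has no number to offer: "not determined" (no result reported). Compound 2 `COC(=O)c1ccc(NCc2cncn2Cc2ccc(C#N)cc2)cc1-c1ccccc1` gives > 10000 nM, which is a limit of the assay and not a number. Among the measured compounds shown here, that limit is the only reading available as a starting point. Compound 3 `COC(=O)c1ccc(NCc2cncn2Cc2ccc(C)cc2)cc1-c1ccccc1` has methyl in place of cyano on an aromatic carbon. For the measured compounds named here, no measured pair of compounds shows what this swap does in this assay. The step expected a step that the limit leaves unreadable from compound 2 to compound 3 is therefore none beyond the usual scatter. The estimated value for compound 3 is 14000 nM, with an expected range from 5000 nM to 40000 nM.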

Compound 3, half-maximal effective concentration: 50000 nM
Beside the measured number, compound 3's estimate is 3.6-fold (0.55 log units) below it; the measured number lies above the stated range.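

Among the compounds shown here, no step of readable size links compound 2 and compound 3 in this assay: the reading for compound 2 is a limit of the assay, not a number. The compounds shown leave open how far methyl in place of cyano shifts the value.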